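The source may hold more compounds than are shown below. What is called first, only, known or untested is meant among the compounds shown, and "the series" means these compounds.

Measured compounds in a physicochemical assay for acid dissociation:
- compound 1 `COc1ccc(F)cc1CNCCCNc1ccnc2cc(C3CCCCC3)ccc12`: 9.47
- compound 2 `COc1cccc(Oc2ccc3c(NCCCNCc4cc(F)ccc4OC)ccnc3c2)c1`: 9.28
- compound 3 `COc1ccc(F)cc1CNCCCNc1ccnc2cc(Oc3ccc(F)cc3)ccc12`: 9.28

Compound 3 is level with compound 2 at the digits printed, and the two share the lowest number of the three. Both of the steps that lead into compound 3 are small: a number 0.19 log units lower from compound 1 to compound 3 (within the scatter) and no change at the digits printed from compound 2 to compound 3 (within the scatter). The third measured step, a number 0.19 log units lower from compound 1 to compound 2 (within the scatter), is equally within the scatter, so within this series the group on that aromatic carbon has not moved the acid dissociation constant beyond noise.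

Compound 4 `COc1ccc(F)cc1CNCCCNc1ccnc2cc(CC3CCCCC3)ccc12` differs from compound 3 in one place: cyclohexylmethyl in place of 4-fluorophenoxy on an aromatic carbon. The step that bears most directly on it is a number 0.19 log units lower from compound 1 to compound 3 (within the scatter), since compound 1 carries cyclohexyl at the same carbon; running that step backwards and replacing cyclohexyl with cyclohexylmethyl is expected to give at most a small rise, a number 0.17 log units higher from compound 3 to compound 4 (within the scatter), not beyond the scatter.

For compound 4 in this assay a value of 9.45 is expected, in the range 9.15 to 9.75.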

Compound 4, acid dissociation constant: 9.47
Compound 4: the middle estimate sits 0.02 log units below what was measured, within the range that was stated.
By their numbers in this assay, from the lowest: compounds 2, 3, 1 and 4 (each within the scatter of the next).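

In this assay, the step to cyclohexylmethyl at this aromatic carbon stays within the scatter from each earlier compound: no change at the digits printed from compound 1 to compound 4 (within the scatter), a number 0.19 log units higher from compound 3 to compound 4 (within the scatter) and a number 0.19 log units higher from compound 2 to compound 4 (within the scatter). The earlier compounds shown here covered cyclohexyl and two substituted phenoxy groups, while compound 4 adds a group of carbon only, with a non-aromatic ring and no hydrogen-bond acceptor. Across these four groups, with or without an oxygen on the aromatic carbon and with either an aromatic or a non-aromatic ring, no step goes beyond the scatter, and nothing available gives a reason for this.

Still open, as far as these compounds go, is whether an amine or a carboxylic acid on this aromatic carbon would leave the reading within the scatter. The compounds shown also leave open what a longer chain in place of the shared chain would do.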